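Series notes: phenyl replacing (pyrrolidin-3-yl)amino on the core

A few compounds are considered here, and "the series" means these few. Any claim that something is new, unique, unknown or untested is made for them only; others in the source may bear on it.

Measured so far:
compound 1 `Cn1cc(-c2n[nH]c3ccc(NC4CCNC4)cc23)cn1` gives 132000 nM
compound 2 `N#Cc1ccc(-n2cc(-c3n[nH]c4cc(Cl)c(N[C@@H]5CCNC5)cc34)cn2)cc1` gives 700 nM
compound 3 `Cc1ccc2nc(C(F)(F)F)cc(N3CCNCC3)c2c1` gives 204000 nM

All three numbers come from an assay on isolated protein for inhibition of tyrosine-protein kinase receptor UFO (Homo sapiens), with a stated time of 1.5 h; a lower number here means a stronger inhibitor, a higher number a weaker inhibitor. Compound 1 sits near the top of the three values: its number and that of compound 3 lie within the usual scatter of each other, so nothing separates them. Compound 2, which carries several changes relative to the shared core of compound 1, gives a far lower number, and that gap is well beyond the scatter. Among the compounds with values here, no pair of measured compounds differs in just one place, so no single change has yet been tied to a shift in this assay.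

Compound 4 `Cn1cc(-c2n[nH]c3ccc(-c4ccccc4)cc23)cn1` is the next step from compound 1. The change is phenyl in place of (pyrrolidin-3-yl)amino on an aromatic carbon. Nothing measured here isolates this exchange, so its effect has to be guessed. Within the data shown here, compound 1 already gives a weak number, and the only far stronger compound, compound 2, keeps the (pyrrolidin-3-yl)amino group that compound 4 loses. The expectation is therefore a step of a 1.4-fold higher number from compound 1 to compound 4 (0.13 log units; within the scatter) of modest size, most likely toward a similar or somewhat higher number, with the direction uncertain. Compound 4 is estimated at 180000 nM, with a range from 45000 nM to 600000 nM, and a fair chance that this assay reports only a limit.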

Compound 4, half-maximal inhibitory concentration: 620 nM
Beside the measured number, compound 4's estimate is 290-fold (2.46 log units) above it; measured number below the stated range.
By their numbers in this assay, from the lowest: compounds 4 and 2 (each within the scatter of the next); then compounds 1 and 3 (each within the scatter of the next).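

In this assay, within the data shown here, phenyl in place of (pyrrolidin-3-yl)amino on this aromatic carbon gives a 210-fold lower number from compound 1 to compound 4 (2.33 log units; beyond the scatter) and is the first single change tied to a shift in the read-out. This position therefore strongly affects the result, and the (pyrrolidin-3-yl)amino group, with its hydrogen-bond donors and acceptors, is not required for compound 4 to reach 620 nM on the shared core. Going by these compounds, no supporting measurement explains the size of this step, so it remains unknown whether it reflects losing the (pyrrolidin-3-yl)amino group, gaining the phenyl, or both.

On these data alone, it remains open whether the result depends on phenyl itself or would also hold for a pyridyl, benzyl or methoxy group at this position. Also unresolved is how this assay would respond to a phenyl ring carrying an aminomethyl group or a carboxylic acid, which would show whether an amine or an acid can be reintroduced on the new ring.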